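Working notes: trifluoromethyl for trifluoromethoxy on compound 3

The source may hold more compounds than are shown below. What is called first, only, known or untested is meant among the compounds shown, and "the series" means these compounds.

Three compounds of the series have been run in a functional assay on A-375 cells (Homo sapiens) for antiproliferative activity, read by MTT assay, with a stated time of 24 h, tested at 0.05 ug/mL; on this read-out lower numbers stand for a weaker effect and higher numbers for a stronger effect at the one concentration tested. Compound 1 `CCc1ccc2nc(C(=O)Nc3c(F)cc(-c4cccc(F)c4)cc3F)c(C)c(O)c2c1` gives 0.68%. Compound 2 `Cc1c(C(=O)Nc2c(F)cc(-c3cccc(F)c3)cc2F)nc2ccc(F)cc2c1O`, carrying fluoro in place of ethyl on an aromatic carbon, gives 0.05%; the step is a number 0.6 percentage points lower from compound 1 to compound 2 (within the scatter). Compound 3 `Cc1c(C(=O)Nc2c(F)cc(-c3cccc(F)c3)cc2F)nc2ccc(OC(F)(F)F)cc2c1O`, with trifluoromethoxy at that same carbon, gives -0.13%. Its number stands together with the other two: a number 0.8 percentage points lower from compound 1 to compound 3 (within the scatter) and a number 0.2 percentage points lower from compound 2 to compound 3 (within the scatter), so compound 3 is not separated from either of them.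

Compound 4 `Cc1c(C(=O)Nc2c(F)cc(-c3cccc(F)c3)cc2F)nc2ccc(C(F)(F)F)cc2c1O` is the next step: trifluoromethyl in place of trifluoromethoxy on an aromatic carbon. For the measured compounds named here, all three measured steps exchange the group on this same aromatic carbon, and none moved this assay beyond the scatter; the nearest precedent, a number 0.2 percentage points lower from compound 2 to compound 3 (within the scatter), also swaps one small group for another at this position. Going by the values given here, no measured step gives ground for expecting more here. The step for compound 4 is therefore expected to be a number 0.1 percentage points higher from compound 3 to compound 4 (within the scatter), that is, nothing beyond the scatter. Compound 4 is estimated at 0%, within a range from -7% to 7%.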

Compound 4, a percentage reported as inhibition, at one concentration (the size of the read-out at that concentration, not a potency): 3.47%
Beside the measured number, compound 4's estimate is 3.5 percentage points below it, and the stated range covers the measured number.
By their numbers in this assay, from the lowest: compounds 3, 2, 1 and 4 (each within the scatter of the next).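

In this assay, trifluoromethyl at this aromatic carbon stays with the other three groups: a number 3.6 percentage points higher from compound 3 to compound 4 (within the scatter), a number 3.4 percentage points higher from compound 2 to compound 4 (within the scatter) and a number 2.8 percentage points higher from compound 1 to compound 4 (within the scatter). Ethyl, fluoro, trifluoromethoxy and trifluoromethyl are thus all unseparated at this position, and exchanging trifluoromethoxy for trifluoromethyl, which removes the oxygen joining the group to the ring, does not separate compound 4 from compound 3 at the one concentration tested. No available data bear on the reason for this result.

From the compounds shown here alone, whether an amine, a carboxylic acid or a longer chain on this aromatic carbon would separate from these four groups remains open. Also open, going by these compounds, is whether the four compounds would stay unseparated at another concentration.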